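Replacing the unsaturated acyl chain with a hydroxymethyl carbonyl

The source may hold more compounds than are shown below. What is called first, only, known or untested is meant among the compounds shown, and "the series" means these compounds.

Compound 1 `CCC/C=C/C(=O)N(Cc1ccc(OC)c(O)c1)c1cc(OC)c(OC)c(OC)c1`: 70 nM
Compound 2 `C=C(C)C(=O)N(Cc1ccc(OC)c(O)c1)c1cc(OC)c(OC)c(OC)c1`: 390 nM
Compound 3 `C/C=C/C(=O)N(Cc1ccc(OC)c(O)c1)c1cc(OC)c(OC)c(OC)c1`: 27 nM

These three compounds were tested in a functional assay on MGC-803 cells (Homo sapiens) for inhibition, read by MTT assay, with a stated time of 48 h; on this read-out higher numbers stand for weaker inhibition and lower numbers for stronger inhibition. Among them compound 3 gives the lowest number, with compound 1 nearest a 2.6-fold lower number from compound 1 to compound 3 (0.41 log units; beyond the scatter) and compound 2 furthest a 14-fold lower number from compound 2 to compound 3 (1.16 log units; beyond the scatter). The next compound is compound 4 `COc1ccc(CN(C(=O)CO)c2cc(OC)c(OC)c(OC)c2)cc1O`. It differs from compound 3 as follows: hydroxymethyl in place of prop-1-en-1-yl on a carbonyl carbon. The measured steps all alter an unsaturated acyl group while keeping its double bond; the step of a 5.6-fold higher number from compound 1 to compound 2 (0.75 log units; beyond the scatter) was the only one to give a markedly higher number. Among the compounds with values here, no measured step removes the double bond or brings in a hydroxymethyl group, so the expectation for compound 4 rests on the whole of this series rather than on one matched step. Compound 4 is therefore expected to show a weaker inhibition in this assay, with a step of roughly a 22-fold higher number from compound 3 to compound 4 (1.35 log units; beyond the scatter). The estimate for compound 4 is 600 nM, within a range of 120 nM to 4000 nM.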

Compound 4, half-maximal inhibitory concentration: 160 nM
Beside the measured number, compound 4's estimate is 3.8-fold (0.57 log units) above it; the range from low to high includes it.
By their numbers in this assay, from the lowest: compound 3; then compound 1; then compound 4; then compound 2.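

Hydroxymethyl, which brings no double bond onto this carbonyl carbon, gives a 5.9-fold higher number from compound 3 to compound 4 (0.77 log units; beyond the scatter) when it replaces prop-1-en-1-yl, yet a 2.4-fold lower number from compound 2 to compound 4 (0.39 log units; beyond the scatter) when it replaces 1-methylethenyl and a 2.3-fold higher number from compound 1 to compound 4 (0.36 log units; beyond the scatter) when it replaces pent-1-en-1-yl. A double bond in this acyl group is therefore not needed for inhibition at this level, and the unsaturated groups fall on both sides of hydroxymethyl. Nothing shown gives a reason for these differences. Still open, going by these compounds, is how an aminomethyl group, a methoxymethyl group or a longer hydroxyalkyl chain would compare with hydroxymethyl at this place.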